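The source may report more compounds than this note shows. Statements on the series, on what has been measured and on what is new or still open speak of the compounds shown alone.

In a functional assay on HOP-62 cells (Homo sapiens) for inhibition, read by sulforhodamine B assay (on this read-out higher numbers stand for weaker inhibition of growth and lower numbers for stronger inhibition of growth), compound 2 `Oc1cccc2[nH]c(-c3ccc(-c4ccc(-c5ccccc5)cc4)cc3)nc12` gives 9040 nM, compound 3 `COc1ccc(-c2ccc(-c3ccc(-c4nc5c(O)cccc5[nH]4)cc3)cc2)cc1` gives 3210 nM, and compound 1 `COc1ccc(-c2ccc(-c3ccc(-c4nc5cc(C)ccc5[nH]4)cc3)cc2)cc1OC` gives 2120 nM. Compound 3 thus lies within the scatter of compound 1, while its number is lower than that of compound 2 by more than the scatter. Compound 4 `COc1ccc(-c2ccc(-c3ccc(-c4nc5c(O)cccc5[nH]4)cc3)cc2)cc1OC` differs from compound 3 in one place: methoxy in place of hydrogen on an aromatic carbon. This is methoxy in place of hydrogen on an aromatic carbon, turning 4-methoxyphenyl into 3,4-dimethoxyphenyl. Among the compounds with values here, the one measured step of the same kind is a 2.8-fold lower number from compound 2 to compound 3 (0.45 log units; beyond the scatter), although there the methoxy enters a ring that carries none. Compound 1 already bears the 3,4-dimethoxyphenyl group, with a different substitution at the other end of the molecule, and its 2120 nM does not separate from the number of compound 3. A small move toward a lower number is therefore expected, probably within the scatter. The expected step is a 1.3-fold lower number from compound 3 to compound 4 (0.11 log units; within the scatter). Compound 4 is estimated at 2500 nM, with an expected range from 1200 nM to 5000 nM.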

Compound 4, concentration for 50% growth inhibition: 2210 nM
For compound 4 the middle estimate is 1.1-fold (0.05 log units) above the measured one, and the stated range covers the measured number.
By their numbers in this assay, from the lowest: compounds 1, 4 and 3 (each within the scatter of the next); then compound 2.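

In this assay, the second methoxy that turns 4-methoxyphenyl into 3,4-dimethoxyphenyl gives a 1.5-fold lower number from compound 3 to compound 4 (0.16 log units; within the scatter) and so leaves the number unseparated at this place, ortho to a methoxy group. Measured against plain phenyl, the 3,4-dimethoxyphenyl group gives a 4.1-fold lower number from compound 2 to compound 4 (0.61 log units; beyond the scatter) and, next to a 2.8-fold lower number from compound 2 to compound 3 (0.45 log units; beyond the scatter) for the single methoxy, shows that the drop from phenyl does not depend on this second methoxy. With 3,4-dimethoxyphenyl in place, 4-hydroxy-1H-benzimidazol-2-yl instead of 5-methyl-1H-benzimidazol-2-yl gives a 1.0-fold higher number from compound 1 to compound 4 (0.02 log units; within the scatter) and so does not separate the two compounds either.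

No measurement shown here offers a reason for any of these steps. On these data alone, whether an amine, a carboxylic acid or a longer alkoxy chain at this same place would separate from methoxy remains open.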